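Notes on a vinyl-for-dimethylamino step in the series

The compounds below may be only part of what the source reports. "The series", "measured", "known", "first", "only" and "open" are said of these compounds alone.

Measured so far in a functional assay on B16-F0 cells (Mus musculus) for inhibition, read by CCK-8 assay, with a stated time of 48 h; on this read-out higher numbers stand for weaker inhibition and lower numbers for stronger inhibition:
Compound 1 `COc1ccc(-c2cc3nccc(-c4cc(OC)c(OC)c(OC)c4)n3n2)cc1[N+](=O)[O-]` gives > 10000 nM, a limit of the assay and not a number.
Compound 2 `COc1cc(-c2cc3nccc(-c4c[nH]c5ccccc45)n3n2)cc(OC)c1OC` gives > 10000 nM, again a limit of the assay.
Compound 3 `COc1cc(-c2ccnc3cc(-c4ccc(N(C)C)cc4)nn23)cc(OC)c1OC` gives 702 nM.

Compound 3 thus holds the only number shown. Compound 1 and compound 2 sit at the limit of > 10000 nM in this assay, at which 2 of the 3 values shown sit. Within the data shown here, no pair of measured compounds differs in a single place, so no measured step is available for comparison, and the size of any structural change in this assay has not yet been read off directly.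

Compound 4 `C=Cc1ccc(-c2cc3nccc(-c4cc(OC)c(OC)c(OC)c4)n3n2)cc1` is not yet measured. It differs from compound 3 by vinyl in place of dimethylamino on an aromatic carbon. Neither compound 1 nor compound 2 shares this change, so the two limits give no direct guide to its size. Among the measured compounds shown here, with no measured step to lean on, the expectation rests only on compound 3 giving 702 nM and on the change itself. A loss of potency of modest size, a little beyond the scatter, is expected for the step of a 2.8-fold higher number from compound 3 to compound 4 (0.45 log units; beyond the scatter). Compound 4 is accordingly estimated at 2000 nM, within the range 600 nM to 8000 nM, with a real chance that the assay returns only a limit.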

Compound 4, half-maximal inhibitory concentration: 788 nM
Compound 4: the middle estimate sits 2.5-fold (0.40 log units) above what was measured, within the range that was stated.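

In this assay, among these compounds, vinyl in place of dimethylamino gives a 1.1-fold higher number from compound 3 to compound 4 (0.05 log units; within the scatter), the only measured step so far. On this aromatic carbon, para to a large group, the read-out therefore does not separate the two groups, although dimethylamino brings a nitrogen and a hydrogen-bond acceptor and vinyl brings neither, but does bring a double bond. Among the compounds shown here, for this pair, then, neither that nitrogen nor that acceptor is required for inhibition in the range of compound 3, which the earlier compounds, with no single-place step among them, could not show.

Nothing measured here speaks to why the two groups read alike. Still open, on these data alone, is whether the same holds for other groups at this place, such as a primary amine, a carboxylic acid, a morpholine or a longer alkyl chain, and whether a change at this place behaves the same way when the trimethoxyphenyl group of compound 3 and compound 4 is replaced.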